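The compounds below may be only part of what the source reports. "The series", "measured", "known", "first", "only" and "open" are said of these compounds alone.

The measured compounds:

Compound 1, `CCCCCCc1ccc(C(=O)N/N=C/c2ccc([N+](=O)[O-])o2)cc1`: in an ADME assay on U2OS cells (Homo sapiens) for cytotoxicity (a higher number here means that more compound is tolerated, a lower number that less compound is tolerated), compound 1 is recorded only as a limit of the assay, > 200000 nM.
Compound 2, `CCCCc1ccc(C(=O)N/N=C/c2ccc([N+](=O)[O-])o2)cc1`: in this assay compound 2 gives 19600 nM.
Compound 3, `O=C(N/N=C/c1ccc([N+](=O)[O-])o1)c1ccc2ccccc2c1`: in this assay compound 3 gives 64200 nM.

Of the two numbers, compound 2 stands lowest, and compound 3 gives a higher number, beyond the scatter. Among the measured compounds shown here, the only measured step, an at least 10-fold lower number from compound 1 to compound 2 (1.00 log units; beyond the scatter), concerns the length of the alkyl chain, and its starting point is a limit, (the limit of > 200000 nM in this assay, at which 1 of the 3 values shown sits), so its full size is not known.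

Compound 4, `CCCCOc1ccc(C(=O)N/N=C/c2ccc([N+](=O)[O-])o2)cc1`, differs from compound 2 by butoxy in place of butyl on an aromatic carbon. For the measured compounds named here, no measured step exchanges a chain carbon for an oxygen at this place, and the chain-length step between compound 1 and compound 2 does not speak to it. The expected step is therefore a 1.3-fold higher number from compound 2 to compound 4 (0.11 log units; within the scatter), within the usual scatter. Compound 4 is estimated at 25000 nM, with a range from 10000 nM to 60000 nM.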

Compound 4, half-maximal cytotoxic concentration: 46600 nM
Compound 4: the middle estimate sits 1.9-fold (0.27 log units) below what was measured; the measured number falls inside the stated range.
By their numbers in this assay, from the lowest: compound 2; then compounds 4 and 3 (each within the scatter of the next). At a limit, above all of these: compound 1.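

Putting butoxy in place of butyl on an aromatic carbon gives a 2.4-fold higher number from compound 2 to compound 4 (0.38 log units; beyond the scatter) in this assay and so shows that, at this place, the number moves with more than the length of the alkyl chain. An oxygen entering at the aromatic carbon, with the four chain carbons kept, is enough to shift it beyond the scatter. Butoxy in place of hexyl gives an at least 4.2-fold lower number from compound 1 to compound 4 (0.63 log units; beyond the scatter) but compound 1 is recorded only as a limit, so the full size of that step is not known: the limit of > 200000 nM in this assay, at which 1 of the 4 values shown sits.

On these data alone, whether hexyloxy would match hexyl at this place remains open. So does whether an amine nitrogen in place of the oxygen, joined to the same butyl chain, would give a number like that of butoxy or of butyl.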